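Phenylsulfonyl for aryloxy at the quaternary carbon

A few compounds are considered here, and "the series" means these few. Any claim that something is new, unique, unknown or untested is made for them only; others in the source may bear on it.

Compound 3 `CC(C)(Oc1ccccc1O)C1OCC(C/C=C\CCC(=O)O)C(c2cccnc2)O1` gives 32 nM in an assay for inhibition of Thromboxane-A synthase (Homo sapiens), using microsomes; a lower number here means a stronger inhibitor, a higher number a weaker inhibitor. Compound 1 `COc1ccc(OC(C)(C)C2OCC(C/C=C\CCC(=O)O)C(c3cccnc3)O2)cc1` gives 41 nM and compound 2 `CSc1ccccc1OC(C)(C)C1OCC(C/C=C\CCC(=O)O)C(c2cccnc2)O1` gives 36 nM; compound 3 cannot be told apart from either, as the steps of a 1.3-fold lower number from compound 1 to compound 3 (0.11 log units; within the scatter) and a 1.1-fold lower number from compound 2 to compound 3 (0.05 log units; within the scatter) show, and the step of a 1.1-fold lower number from compound 1 to compound 2 (0.06 log units; within the scatter) is likewise flat. Compound 4 `CC(C)(C1OCC(C/C=C\CCC(=O)O)C(c2cccnc2)O1)S(=O)(=O)c1ccccc1` differs from compound 3 by phenylsulfonyl in place of 2-hydroxyphenoxy on a saturated chain carbon bound to two saturated chain carbons and a saturated ring carbon. The three measured steps only exchange the aryl group or its ring substituent while the oxygen stays; none removes that oxygen, so they bear on compound 4 only loosely, showing merely that variation at this carbon has so far moved this assay little. A number near the present ones is therefore expected, with a wide band. For compound 4 the estimate is 45 nM (15 nM to 150 nM). This means an expected step of a 1.4-fold higher number from compound 3 to compound 4 (0.15 log units; within the scatter).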

Compound 4, half-maximal inhibitory concentration: 40 nM
Compound 4: the middle estimate sits 1.1-fold (0.05 log units) above what was measured; the measured number falls inside the stated range.
By their numbers in this assay, from the lowest: compounds 3, 2, 4 and 1 (each within the scatter of the next).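

Replacing the aryloxy group with phenylsulfonyl removes the oxygen on the saturated chain carbon, yet this assay stays flat against all three earlier compounds (a 1.3-fold higher number from compound 3 to compound 4 (0.10 log units; within the scatter); a 1.1-fold higher number from compound 2 to compound 4 (0.05 log units; within the scatter); a 1.0-fold lower number from compound 1 to compound 4 (0.01 log units; within the scatter)). Among these four compounds, neither that oxygen nor the hydrogen-bond donor of 2-hydroxyphenoxy is needed for a number in this range. No supporting data explain this tolerance.

Open, on these data alone, is whether an aromatic ring is needed here at all, which a methyl or an amine on this carbon would test. The matching phenyl sulfide would separate the sulfur from the two sulfonyl oxygens.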